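The source may hold more compounds than are shown below. What is called first, only, known or untested is meant among the compounds shown, and "the series" means these compounds.

For the measured compounds named here, compound 2 `Cc1cccc(C(=O)OC(CCN(C)C)c2ccc(Cl)cc2)c1C` is one of two compounds measured in an assay on NIH3T3 cells with Urotensin-2 receptor (Homo sapiens) as the target (a higher number here means that more compound is needed for the effect, a lower number that less compound is needed), where it gives 1150 nM. Going by the values given here, its only neighbour is compound 1 `COc1ccc(C(=O)OC(CCN(C)C)c2ccc(Cl)cc2)cc1`, which in this assay gives 2190 nM; the step of a 1.9-fold lower number from compound 1 to compound 2 (0.28 log units; within the scatter) lies within the scatter, so compound 2 cannot be called the more potent of the pair. Compound 3 `Cc1ccc(C)c(C(=O)OC(CCN(C)C)c2ccc(Cl)cc2)c1` has not yet been measured. It differs from compound 2 by 2,5-dimethylphenyl in place of 2,3-dimethylphenyl on a carbonyl carbon. The single measured step bears on the aromatic group attached to the carbonyl carbon and was within the scatter, and no measured pair separates two dimethyl arrangements of that ring, so there is no shown ground for a shift in either direction. The account therefore expects no step beyond the scatter, a 1.1-fold higher number from compound 2 to compound 3 (0.05 log units; within the scatter). Compound 3 is estimated at 1300 nM, within a range from 500 nM to 3500 nM.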

Compound 3, half-maximal effective concentration: 1860 nM
Beside the measured number, compound 3's estimate is 1.4-fold (0.16 log units) below it; low and high end bracket the measured number.
By their numbers in this assay, from the lowest: compounds 2, 3 and 1 (each within the scatter of the next).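

Moving one methyl group, with 2,5-dimethylphenyl in place of 2,3-dimethylphenyl on the carbonyl carbon, gives the first pair that separates two dimethyl arrangements of this ring, and in this assay the change amounts to (a 1.6-fold higher number from compound 2 to compound 3 (0.21 log units; within the scatter)). The 2,5-dimethylphenyl group also stands level with 4-methoxyphenyl (a 1.2-fold lower number from compound 1 to compound 3 (0.07 log units; within the scatter)), so none of the three aromatic groups at this position can be told apart by this read-out. Nothing available accounts for these numbers.

Going by these compounds, it remains open whether any group on this carbonyl carbon can move the number beyond the scatter, for instance a pyridine ring, a carboxylic acid or a longer chain. The compounds shown also leave open what an amide in place of the ester would do.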